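Inverting one ring stereocentre of a deprotected iminosugar amine

The source may report more compounds than this note shows. Statements on the series, on what has been measured and on what is new or still open speak of the compounds shown alone.

Compound 1 `O=C(/C=C/c1ccc(C(F)(F)F)cc1)NC[C@H]1NC[C@H](O)[C@@H](O)[C@H]1O`: 99%
Compound 2 `NC[C@@H]1NC[C@H](O)[C@H](O)[C@H]1O`: 45%

In an assay on isolated protein for inhibition of alpha-galactosidase A (Homo sapiens), read by fluorescence, tested at 100 uM (on this read-out lower numbers stand for less inhibition and higher numbers for more inhibition at the one concentration tested (going by the name of the read-out)), compound 1 gives 99%, whereas compound 2 gives 45%, the lower of the two numbers shown and a gap well beyond the usual scatter. Compound 3 `NC[C@@H]1NC[C@H](O)[C@@H](O)[C@H]1O` has not yet been measured in this assay. Its relation to compound 2 is confined to configuration: the two compounds have the same atoms and bonds and differ only in configuration as drawn: 1 of 4 stereo elements differ; a stereocentre at a saturated ring carbon is drawn S in compound 2 and R in compound 3. Within the data shown here, with no measured pair that differs only in this way, the size and direction of the step from compound 2 to compound 3 rest on judgement alone. A change of configuration at a ring carbon in a compound of this kind could move the read-out in either direction, and a step of moderate size is expected, with the direction uncertain. Compound 3 is therefore estimated at 55%, with a range from 20% to 88%, which corresponds to an expected step of a number 10 percentage points higher from compound 2 to compound 3 (within the scatter).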

Compound 3, a percentage reported as inhibition, at one concentration (the size of the read-out at that concentration, not a potency): 30%
Estimate against measurement, compound 3: 25 percentage points above; the measured number falls inside the stated range.
By their numbers in this assay, from the lowest: compound 3; then compound 2; then compound 1.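

In this assay, drawing this saturated ring carbon R instead of S gives a number 15 percentage points lower from compound 2 to compound 3 (beyond the scatter), so for this pair the direction of the change is now known: the S form reads higher. Configuration at this one carbon is enough on its own to shift the read-out, and the shift can be assigned to that carbon alone because nothing else separates the pair: the fact that compounds 2 and 3 differ only in the configuration as drawn. The change lowers the number without removing it, since compound 3 still gives 30% at the one concentration tested.

Left open is whether the same inversion would move the number in the same direction if the amine carried an acyl group, such as an acetyl amide, instead of staying free. Also open, as far as these compounds go, is how a carboxylic acid or a longer chain in place of that amine would read at either configuration.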